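The compounds below may be only part of what the source reports. "The series", "measured", "known", "first", "only" and "open" are said of these compounds alone.

Of the compounds shown here, three built on a shared core have been measured in an assay on HEK293 cells for inhibition of Voltage-dependent T-type calcium channel subunit alpha-1H (Homo sapiens), read by patch clamp, using a membrane potential dye; on this read-out lower numbers stand for stronger inhibition and higher numbers for weaker inhibition. Compound 1 `CN1CC2(CCN(C(=O)Nc3cc(F)cc(F)c3)CC2)C1c1ccc(Cl)cc1` gives 214 nM in this assay. Compound 2 `CN1C(=O)C2(CCN(C(=O)Nc3cc(F)cc(F)c3)CC2)C1c1ccc(Cl)cc1` gives 920 nM in this assay. Compound 3 `CC[C@H](C)[C@H](NC(=O)N1CCC2(CC1)C(=O)N(c1cccc(F)c1)C2c1ccc(Cl)cc1)C(=O)OC(C)C` gives 45 nM in this assay, the lowest of the three numbers; its gap to compound 1 and its gap to compound 2 both lie beyond the usual scatter, so compound 3 is the strongest inhibitor of the three.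

Compound 4 `COC(=O)[C@H](C)NC(=O)N1CCC2(CC1)C(=O)N(c1cccc(F)c1)C2c1ccc(Cl)cc1` is not yet measured. It differs from compound 3 at one place: a group of 6 heavy atoms (4 carbon, 2 oxygen; no ring) in place of a group of 11 heavy atoms (9 carbon, 2 oxygen; no ring), on an amide-type nitrogen. Within the data shown here, no measured pair shows this change, so the size of the step is uncertain. A modest move towards a higher number is expected for compound 4, with the step from compound 3 to compound 4 estimated as a 3.3-fold higher number from compound 3 to compound 4 (0.52 log units; beyond the scatter). Compound 4 is expected to give about 150 nM in this assay, within a range from 40 nM to 600 nM.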

Compound 4, half-maximal inhibitory concentration: 827 nM
Compound 4: middle estimate off by 5.5-fold (0.74 log units), on the low side; measured number above the stated range.
By their numbers in this assay, from the lowest: compound 3; then compound 1; then compounds 4 and 2 (each within the scatter of the next).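

Replacing the group of 11 heavy atoms on the amide-type nitrogen with 1-(methoxycarbonyl)ethyl gives, in this assay, an 18-fold higher number from compound 3 to compound 4 (1.26 log units; beyond the scatter), so the inhibition seen in this series is sensitive to the group at this position. The change lowers the carbon count and removes one defined stereocentre, while the counts of hydrogen-bond donors and acceptors stay the same, so the large step arises without any change in those counts. Nothing measured on these compounds explains the step.

The compounds shown leave open which part of the change matters, since the carbon count, the stereocentre and the ester's own alkyl part all differ at once. They also leave open how a carboxylic acid, an amine or a longer chain would read on this nitrogen.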